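Aryl substituent swap on the ketone: methoxy to fluoro

This account rests on a few compounds, and the source may have more. Where it says the series, first, only, none or still open, it means among the compounds named here.

Measured so far:
compound 1 `COc1ccccc1C(=O)c1sc2nc(-c3cccs3)ccc2c1N` gives 0.059 ug/mL in a functional assay on WI-38 VA13 cells (Homo sapiens) for cytotoxicity; on this read-out lower numbers stand for an effect already at smaller amounts and higher numbers for an effect only at larger amounts of compound
compound 2 `CCC(=O)c1sc2nc(-c3cccs3)ccc2c1N` gives 0.89 ug/mL in this assay
compound 3 `COc1cccc(C(=O)c2sc3nc(-c4cccs4)ccc3c2N)c1` gives 0.03 ug/mL in this assay

Compound 3 has the lowest number of the three in this assay, but the step of a 2.0-fold lower number from compound 1 to compound 3 (0.29 log units; within the scatter) is within the scatter; only compound 2 stands clearly apart, with a 30-fold lower number from compound 2 to compound 3 (1.47 log units; beyond the scatter) and a 15-fold higher number from compound 1 to compound 2 (1.18 log units; beyond the scatter).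

Compound 4 `Nc1c(C(=O)c2cccc(F)c2)sc2nc(-c3cccs3)ccc12` is not yet measured. It differs from compound 3 by fluoro in place of methoxy on an aromatic carbon, that is, 3-methoxyphenyl becomes 3-fluorophenyl on the carbonyl carbon. Going by the values given here, the only step bearing on a change of the substituent on that aryl ring is the move from compound 1 to compound 3, which was within the scatter. The large steps in the series concern ethyl against an aryl group, which compound 4 keeps. A step beyond the scatter is therefore not expected; compound 4 is estimated at 0.04 ug/mL, a step of a 1.3-fold higher number from compound 3 to compound 4 (0.12 log units; within the scatter), with a range from 0.012 ug/mL to 0.13 ug/mL.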

Compound 4, half-maximal effective concentration: 0.025 ug/mL
Compound 4: middle estimate off by 1.6-fold (0.20 log units), on the high side; the range from low to high includes it.
By their numbers in this assay, from the lowest: compounds 4, 3 and 1 (each within the scatter of the next, the first and the last beyond it); then compound 2.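

At this position on the aromatic ring, fluoro can stand in for methoxy in this assay with no step beyond the scatter, as a 1.2-fold lower number from compound 3 to compound 4 (0.08 log units; within the scatter) shows, even though one heavy atom replaces two and the hydrogen-bond acceptor is lost. Going by these compounds alone, the aryl ketone keeps its large lead over the ethyl ketone with this new substituent, at a 36-fold lower number from compound 2 to compound 4 (1.55 log units; beyond the scatter), while a 2.4-fold lower number from compound 1 to compound 4 (0.37 log units; beyond the scatter) is the first modest step between aryl ketones, although that pair differs in both the substituent and its place on the ring. No available evidence accounts for these results.

Still open, from the compounds shown here alone, is whether an amine or a carboxylic acid on the same aromatic carbon would stay in this range. Also open, going by these compounds, is whether fluoro on the carbon that bears methoxy in compound 1 would match compound 4.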